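The compounds below may be only part of what the source reports. "The series", "measured", "known", "first", "only" and "open" are said of these compounds alone.

Three compounds sharing one core were examined in an assay on isolated protein for binding affinity to 5-hydroxytryptamine receptor 1E (Homo sapiens); a lower number here means a stronger inhibitor, a higher number a weaker inhibitor. Compound 1 `Cc1ccc(-c2n[nH]cc2N2CCCNCC2)cc1` gives > 10000 nM in this assay, which is a limit of the assay and not a number. Compound 2 `Fc1cccc(-c2n[nH]cc2N2CCCNCC2)c1` gives > 10000 nM, again a limit. Compound 3 `COc1ccccc1-c1n[nH]cc1N1CCNCC1` gives > 10000 nM, also a limit, so compound 3 stands at the limit of > 10000 nM in this assay, at which 3 of the 3 values shown sit. Within the data shown here, no number is known for any of the three, and no step between them can be sized. Compound 4 `Fc1ccccc1-c1n[nH]cc1N1CCNCC1` differs from compound 3 by fluoro in place of methoxy on an aromatic carbon. Among the measured compounds shown here, with every value so far at the limit, the step expected in this assay is a step that the limit leaves unreadable from compound 3 to compound 4, none beyond the scatter. Compound 4 is therefore estimated at 15000 nM, within a range from 4000 nM to 60000 nM, most likely reported only as a limit.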

Compound 4, inhibition constant: > 10000 nM
Compound 4: only a limit was reported; the forecaster's own chance of this, stated with the estimate: 85%; the middle value lies beyond the limit too.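

Among these compounds, compound 3 and compound 4 both stand only at a limit, so no step from one to the other can be read. The compounds shown leave open how strongly any of them binds in this assay, as every value is a limit: the limit of > 10000 nM in this assay, at which 4 of the 4 values shown sit.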